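Trifluoroacetyl for Dimethylcarbamoyl in a Permeability Series

This account rests on a few compounds, and the source may have more. Where it says the series, first, only, none or still open, it means among the compounds named here.

The account concerns two measured compounds and one awaiting measurement, all sharing one core. Compound 1 `CCN(c1cc2oc(-c3ccc(F)cc3)c(C(=O)NC)c2cc1-c1cc(F)c(OC)c(C(=O)NC2(c3ncccn3)CC2)c1)S(C)(=O)=O` was tested in an ADME assay on Caco-2 cells (Homo sapiens) for permeability, read by LC-MS, with a stated time of 2 h, tested at 3 uM (a higher number here means that the compound crosses the layer faster, a lower number that the compound crosses the layer more slowly), and in that setting compound 1 gives 29 nm/s. Compound 2 `CCN(C(=O)N(C)C)c1cc2oc(-c3ccc(F)cc3)c(C(=O)NC)c2cc1-c1ccc(OC)c(C(=O)NC2(c3ncccn3)CC2)c1` in this assay gives 20 nm/s, and the two numbers lie within the usual scatter of each other, so nothing separates compound 2 from compound 1 on the evidence at hand.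

Compound 3 `CCN(C(=O)C(F)(F)F)c1cc2oc(-c3ccc(F)cc3)c(C(=O)NC)c2cc1-c1ccc(OC)c(C(=O)NC2(c3ncccn3)CC2)c1` has not been measured. It differs from compound 2 in one place: trifluoromethyl in place of dimethylamino on a carbonyl carbon, the same difference reading, one bond further out, as dimethylcarbamoyl to (trifluoromethyl)carbonyl. Going by the values given here, no pair of measured compounds carries this change, so no measured step guides the expectation.

On that basis the step from compound 2 to compound 3 is expected to be small, a 1.5-fold higher number from compound 2 to compound 3 (0.18 log units; within the scatter), most likely not beyond the scatter, with a slight lean toward a higher number. Compound 3 is therefore estimated in this assay at 30 nm/s, with a range from 12 nm/s to 75 nm/s.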

Compound 3, apparent permeability: 42 nm/s
Compound 3: the middle estimate sits 1.4-fold (0.15 log units) below what was measured; the measured number falls inside the stated range.
By their numbers in this assay, from the lowest: compounds 2, 1 and 3 (each within the scatter of the next, the first and the last beyond it).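

Going by these compounds alone, at this position, a carbonyl carbon whose other neighbour is an amide-type nitrogen, trifluoromethyl in place of dimethylamino gives in this assay a 2.1-fold higher number from compound 2 to compound 3 (0.32 log units; beyond the scatter) and so supplies the only step that can be read at a single place. The result shows that a change here, with no ring and no hydrogen-bond donors or acceptors in either the leaving or the entering group, can move the number just past the usual scatter, with compound 3 on the higher side of compound 2. No measured property is available to account for this step, which therefore stands as an observation on one pair.

One pair cannot show whether the step belongs to trifluoromethyl itself or would also appear with another group on this carbonyl carbon, such as a plain methyl, a methoxy or a morpholine. Nor can it show whether the same exchange would give a step of similar size elsewhere in the series, since compound 1 differs from compound 2 in more than one place and offers no second pair.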